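Chloro for hydrogen on the benzoate of compound 2

A few compounds are considered here, and "the series" means these few. Any claim that something is new, unique, unknown or untested is made for them only; others in the source may bear on it.

Three compounds sharing one core were examined in an ADME assay on HepG2 cells (Homo sapiens) for cytotoxicity, read by MTT assay, with a stated time of 24 h; on this read-out higher numbers stand for lower toxicity in this test and lower numbers for higher toxicity in this test. Compound 1 `CN(C)c1ccc(-c2cn(-c3ccnc4cc(Cl)ccc34)nn2)cc1` reached only the limit of the test, giving > 2860000 nM. Compound 2 `O=C(OCc1cn(-c2ccnc3cc(Cl)ccc23)nn1)c1ccccc1` likewise reached only the limit, giving > 2740000 nM. Compound 3 `COc1c(F)c(F)cc(C(=O)OCc2cn(-c3ccnc4cc(Cl)ccc34)nn2)c1F` also gave just a limit, > 2230000 nM. Within this assay, therefore, compound 2 stands among three values that are all limits rather than numbers, and no step between any two of them can be read; the three lines (the limit of > 2230000 nM in this assay, at which 1 of the 3 values shown sits), the limit of > 2740000 nM in this assay, at which 1 of the 3 values shown sits, and the limit of > 2860000 nM in this assay, at which 1 of the 3 values shown sits, each hold one of the three values shown.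

Compound 4 `O=C(OCc1cn(-c2ccnc3cc(Cl)ccc23)nn1)c1ccc(Cl)cc1` differs from compound 2 in one place: chloro in place of hydrogen on an aromatic carbon. Among the compounds with values here, no step in this assay between two measured compounds is available to guide the expectation, and none of the three values shown is a number. The step from compound 2 to compound 4, estimated as an at least 1.0-fold lower number from compound 2 to compound 4 (0.00 log units; that floor lies within the scatter), is expected to stay within the usual scatter, with no direction to be claimed. Compound 4 is therefore expected to give about 2700000 nM in this assay, plausibly between 1000000 nM and 5000000 nM, and most likely again only a limit rather than a number.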

Compound 4, half-maximal cytotoxic concentration: 484000 nM
Estimate against measurement, compound 4: 5.6-fold (0.75 log units) above; the measured number lies below the stated range.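

Replacing hydrogen with chloro on an aromatic carbon of the benzoate ring, para to a large group, gives an at least 5.6-fold lower number from compound 2 to compound 4 (0.75 log units; beyond the scatter) in this assay and so shows that this position is not silent: on this read-out the lower number stands for higher toxicity in this test. Compound 4 is the only one of the four compounds shown to give a number rather than a limit, and the change from phenyl to 4-chlorophenyl is all that separates it from compound 2, so one added chlorine on this ring is enough to bring the value within the measured range. Nothing measured here accounts for the change.

As far as these compounds go, whether the step belongs to chloro itself, or would also follow from an amine or a carboxylic acid at the same place or from chloro elsewhere on the ring, stays open. From the compounds shown here alone, the true size of the step also stays open, as compound 2 gives only a limit, and the steps among compound 1, compound 2 and compound 3 cannot be read, all three values being limits.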